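This account rests on a few compounds, and the source may have more. Where it says the series, first, only, none or still open, it means among the compounds named here.

Measured in an ADME assay on a cell-free system (plasma, Homo sapiens) for metabolic stability, read by LC-MS; on this read-out higher numbers stand for a longer-lived compound and lower numbers for a shorter-lived compound:
- Compound 1 `CCCCCCOC(=O)c1cccc(-c2cc(C(=O)Nc3ccncc3)ccc2CN)c1` gives 0.833 h
- Compound 2 `NCc1ccc(C(=O)Nc2ccncc2)cc1-c1cccc(C(=O)OCc2ccccc2)c1` gives 1.07 h
- Compound 3 `NCc1ccc(C(=O)Nc2ccncc2F)cc1-c1cccc(C(=O)OCC2CCCO2)c1` gives < 0.0834 h as a limit and not a number

Compound 3 has no numeric half-life, and its position is the limit of < 0.0834 h in this assay, at which 1 of the 3 values shown sits.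

The next compound is compound 4 `COC(=O)c1cccc(-c2cc(C(=O)Nc3ccncc3F)ccc2CN)c1`. The change is hydrogen in place of oxolan-2-yl on a saturated chain carbon bound to an oxygen next to a carbonyl group, so (oxolan-2-yl)methoxy gives way to methoxy (hydrogen in place of oxolan-2-yl on a saturated chain carbon bound to an oxygen next to a carbonyl group).

One measured step falls at this same place, showing a 1.3-fold higher number from compound 1 to compound 2 (0.11 log units; within the scatter) for phenyl in place of pentyl. Among the compounds with values here, that single step is small, and it offers no precedent for a large shift from this kind of change. The starting point for the new step is only a limit, so its size stays poorly defined. A rise in this assay is still the expected direction, and the chance of another limit remains real.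

The expected step is an at least 4.7-fold higher number from compound 3 to compound 4 (0.68 log units; beyond the scatter) on this reading. Compound 4 is estimated at 0.4 h with an expected range from 0.08 h to 1.5 h for now.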

Compound 4, half-life: 1.08 h
For compound 4 the middle estimate is 2.7-fold (0.43 log units) below the measured one; low and high end bracket the measured number.
By their numbers in this assay, from the lowest: compounds 1, 2 and 4 (each within the scatter of the next). At a limit, below all of these: compound 3.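

In this assay the place on a saturated chain carbon bound to an oxygen next to a carbonyl group now shows a large step, an at least 12-fold higher number from compound 3 to compound 4 (1.11 log units; beyond the scatter) when methoxy replaces (oxolan-2-yl)methoxy. Within the data shown here, the only earlier step at this place, a 1.3-fold higher number from compound 1 to compound 2 (0.11 log units; within the scatter) for phenyl in place of pentyl, gave no sign that a change here could move the number this far. The half-life of compound 3 is a limit and not a number, so the step has a floor but no upper end: the limit of < 0.0834 h in this assay, at which 1 of the 4 values shown sits.

Among these compounds, only one pair carries the oxolan-2-yl group, so it stays open whether that group alone accounts for the large step or whether other groups at this place would give a similar one. An ethyl group, a longer chain ending in an amine, or a carboxylic acid in place of ((oxolan-2-yl)methoxy)carbonyl would each be a further test of how far the half-life moves with a change at this place.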